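The source may report more compounds than this note shows. Statements on the series, on what has been measured and on what is new or still open speak of the compounds shown alone.

For the measured compounds named here, compound 3 `CN1CCC2=CC[C@H](O)C[C@@H]21` is one of three compounds so far tested in an assay on HEK293 cells for antagonist activity at Neuronal acetylcholine receptor; alpha3/beta4 (Rattus norvegicus), read by FLIPR, using a membrane potential dye; on this read-out higher numbers stand for weaker inhibition and lower numbers for stronger inhibition. In this assay compound 3 gives > 300000 nM, which is a limit of the assay rather than a measured number. Compound 1 `CO[C@H]1CC=C2CCN(C)[C@H]2C1` gives > 300000 nM in this assay, again a limit. Compound 2 `CO[C@H]1CC=C2CCN[C@H]2C1` gives > 300000 nM in this assay, also a limit. All three compounds therefore sit at the same place, (the limit of > 300000 nM in this assay, at which 3 of the 3 values shown sit), and as a consequence neither a step that the two limits leave unreadable from compound 1 to compound 2 nor a step that the two limits leave unreadable from compound 1 to compound 3 can be read in size or direction.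

Compound 4 `O[C@H]1CC=C2CCN[C@H]2C1` is still to be measured in this assay. It differs from compound 3 by hydrogen in place of methyl on an amine nitrogen in a ring. The same kind of change, hydrogen in place of methyl on an amine nitrogen in a ring, is seen in a step that the two limits leave unreadable from compound 1 to compound 2, which leaves no readable size. Going by the values given here, compound 3 starts at the limit, and the one comparable step shows no readable movement, so no step beyond the scatter can be expected in either direction in this assay. Compound 4 is therefore expected to give 300000 nM, somewhere between 100000 nM and 1000000 nM, most probably reported once more as a limit. This expectation amounts to an estimated step of a number no higher from compound 3 to compound 4 (the limit leaves the size open).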

Compound 4, half-maximal inhibitory concentration: > 300000 nM
Compound 4: no number, only a limit; the forecaster's own chance of this, stated with the estimate: 85%; the middle value sits exactly at the limit.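

For the compounds shown here, compound 4 also sits at a limit, so its comparisons with compound 2 and compound 3 yield no new readable step: the limit of > 300000 nM in this assay, at which 4 of the 4 values shown sit.

The compounds shown leave open whether any change to the shared core would give a measurable inhibition in this assay, and how large a step either replacement of methyl by hydrogen can produce.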